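Cytotoxicity on Human Fibroblasts of Selenium-Bearing Naphthoquinone Esters

The source may report more compounds than this note shows. Statements on the series, on what has been measured and on what is new or still open speak of the compounds shown alone.

Measured compounds:
- compound 1 `CC1=C([Se]CC(OC(=O)CC[Se]c2ccccc2)C(=O)NCCCCCC(=O)OCc2ccccc2)C(=O)c2ccccc2C1=O`: 6000 nM
- compound 2 `CC1=C([Se]CC(OC(=O)[C@@H](CO)NC(=O)OC(C)(C)C)C(=O)NC(C)(C)C)C(=O)c2ccccc2C1=O`: 7000 nM

In an ADME assay on PHF cells (Homo sapiens) for cytotoxicity, read by MTT assay, with a stated time of 24 h (on this read-out lower numbers stand for stronger inhibition and higher numbers for weaker inhibition), compound 1 gives 6000 nM and compound 2 gives 7000 nM. Compound 1 has the lowest of the two numbers, but its nearest neighbour, compound 2, lies within the usual scatter of it, so the two values cannot be told apart on this read-out. Both compounds share the same core and differ in the ester attached to the side chain.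

Compound 3 `CC1=C([Se]CC(OC(=O)CNC(=O)OC(C)(C)C)C(=O)NCCCCCC(=O)OCc2ccccc2)C(=O)c2ccccc2C1=O` has not yet been measured in this assay. It is derived from compound 1 by one change: a group of 8 heavy atoms (5 carbon, 1 nitrogen, 2 oxygen; no ring) in place of a group of 8 heavy atoms (7 carbon, 1 selenium; one six-membered aromatic ring of carbon only), on a saturated chain carbon bound to a carbonyl carbon. Within the data shown here, no step between two measured compounds is available to calibrate this change. What can be said is that compound 2, which also carries a (tert-butoxycarbonyl)amino group on the chain carbon bound to the carbonyl carbon, sits within the scatter of compound 1. Accordingly compound 3 is expected to show no step beyond the scatter, with an estimated step of a 1.2-fold higher number from compound 1 to compound 3 (0.07 log units; within the scatter) from compound 1. The value of compound 3 is thus estimated at 7000 nM, between 3000 nM and 16000 nM.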

Compound 3, half-maximal inhibitory concentration: 6000 nM
The estimate for compound 3 lay 1.2-fold (0.07 log units) above the measured number; measured number inside the range.
By their numbers in this assay, from the lowest: compounds 1, 3 and 2 (each within the scatter of the next).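

In this assay, the saturated chain carbon bound to a carbonyl carbon now has its first readable exchange: (tert-butoxycarbonyl)amino in place of the group holding selenium and a six-membered aromatic ring of carbon gives no change at the digits printed from compound 1 to compound 3 (within the scatter). The read-out therefore does not separate these two groups at this place, even though the entering group has no ring or selenium and brings a hydrogen-bond donor and hydrogen-bond acceptors that the leaving group lacks. No measurement shown here accounts for this outcome.

What the compounds shown leave open is whether this insensitivity extends to other groups at the same carbon, such as a free primary amine, a carboxylic acid or a longer alkyl chain. They also leave open whether a phenyl ring alone, without the selenium atom, would give a number distinct from those of compound 1 and compound 3 on this read-out.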